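Removing the trifluoromethyl: expected cytotoxicity of compound 3

The source may hold more compounds than are shown below. What is called first, only, known or untested is meant among the compounds shown, and "the series" means these compounds.

Values in an ADME assay on Huh-7 cells (Homo sapiens) for cytotoxicity, read by MTT assay, with a stated time of 72 h; on this read-out lower numbers stand for higher toxicity in this test and higher numbers for lower toxicity in this test:
- compound 1 `COc1cccc(-c2cc(C(F)(F)F)c3c(N)c(C(N)=O)sc3n2)c1` gives > 20000 nM, a limit of the assay.
- compound 2 `COc1ccccc1-c1cc(C(F)(F)F)c2c(N)c(C(N)=O)sc2n1` gives > 20000 nM, also a limit of the assay.

Compound 1 stands only at a limit of this assay, not at a number. The same holds for the one other value shown, so both shown values sit at the limit (the limit of > 20000 nM in this assay, at which 2 of the 2 values shown sit). Among the measured compounds shown here, the one step among measured compounds, a step that the two limits leave unreadable from compound 1 to compound 2, is therefore not readable in size or direction from the two limits.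

Compound 3 `COc1cccc(-c2ccc3c(N)c(C(N)=O)sc3n2)c1` differs from compound 1 by hydrogen in place of trifluoromethyl on an aromatic carbon, a hydrogen in place of trifluoromethyl on an aromatic carbon of the shared core. For the measured compounds named here, no measured step bears on this change in a readable way; the only measured step, from compound 1 to compound 2, sits between two limits. Nothing shown points to a step beyond the scatter in this assay in either direction.

For compound 3 a value of about 30000 nM in this assay is expected, with a range from 10000 nM to 100000 nM. This estimate for compound 3 means a step that the limit leaves unreadable from compound 1 to compound 3 from compound 1, and it is expected that the assay again reports only a limit.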

Compound 3, half-maximal cytotoxic concentration: < 400 nM
Compound 3: no number, only a limit; the forecaster's own chance of this, stated with the estimate: 85%; middle value at least 75-fold (1.87 log units) away from the limit.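

Working notes on the series: in this assay, the place opposite the ring nitrogen on the shared core is the first place where a change gives a readable result, as hydrogen in place of trifluoromethyl gives an at least 50-fold lower number from compound 1 to compound 3 (1.69 log units; beyond the scatter). Compound 3 gives < 400 nM, which is a limit of the assay and not a number. The step between the two methoxyphenyl compounds cannot be read, so the trifluoromethyl swap is the only change with a readable step, and it separates two opposite ends of the measurable range in this assay: the limit of > 20000 nM in this assay, at which 2 of the 3 values shown sit.

Going by these compounds, what a small group other than trifluoromethyl, such as a methyl or a chlorine, would give on this aromatic carbon stays open, so it cannot yet be said whether the low number of compound 3 follows from the loss of trifluoromethyl specifically or from the hydrogen at that place. Also open, on these data alone, is whether the 2-methoxyphenyl group of compound 2 would give the same result as the 3-methoxyphenyl group once hydrogen stands in place of trifluoromethyl.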